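Carbamate series: methoxy in place of butoxycarbonyl

The source may report more compounds than this note shows. Statements on the series, on what has been measured and on what is new or still open speak of the compounds shown alone.

For the measured compounds named here, compound 1 `C=C1C(=O)OC[C@H]1CCOC(=O)Nc1ccc(C(=O)OCCCC)cc1` carries the lowest of the two numbers so far, 430 nM in a functional assay on RAW264.7 cells (Mus musculus) for inhibition, with a stated time of 30 min; on this read-out higher numbers stand for weaker inhibition and lower numbers for stronger inhibition; compound 2 `C=C1C(=O)OC[C@@H]1CCOC(=O)Nc1cccc(Br)c1` gives 840 nM in this assay, and the gap between them lies within the scatter. Compound 3 `C=C1C(=O)OC[C@H]1CCOC(=O)Nc1ccc(OC)cc1` differs from compound 1 by methoxy in place of butoxycarbonyl on an aromatic carbon. Going by the values given here, no measured pair shows a change of this kind, so direction cannot be read from the series; a step of modest size, or none beyond the scatter, is expected. For compound 3 in this assay the estimate is 700 nM, ranging from 250 nM to 2000 nM. This expected step is a 1.6-fold higher number from compound 1 to compound 3 (0.21 log units; within the scatter).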

Compound 3, half-maximal inhibitory concentration: 710 nM
Estimate against measurement, compound 3: 1.0-fold (0.01 log units) below; low and high end bracket the measured number.
By their numbers in this assay, from the lowest: compounds 1, 3 and 2 (each within the scatter of the next).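

In this assay, methoxy in place of butoxycarbonyl on this aromatic carbon gives a 1.7-fold higher number from compound 1 to compound 3 (0.22 log units; within the scatter), so the number holds within the scatter even as the group shrinks from 7 heavy atoms to 2. This position therefore accepts both a large and a small group without a readable change in this read-out. No supporting measurement explains this outcome. Going by these compounds, whether a carboxylic acid, an amine or a chain longer than butoxycarbonyl at this aromatic carbon would keep the number in this range remains open.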